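Working notes: sulfonyl side groups, compound 3 to compound 4

This account rests on a few compounds, and the source may have more. Where it says the series, first, only, none or still open, it means among the compounds named here.

Measured in a functional assay, read by fluorescence and spectrophotometry, with a stated time of 1 h; a higher number here means that more compound is needed for the effect, a lower number that less compound is needed:
- compound 1 `O=S(=O)(/C=C/c1ccc(O)c(O)c1)CC1CCC1`: 8800 nM
- compound 2 `C=CCCCCCCS(=O)(=O)/C=C/c1ccc(O)c(O)c1`: 6400 nM
- compound 3 `O=S(=O)(/C=C/c1ccc(O)c(O)c1)CCC1CCCCC1`: 9800 nM

Compound 3, at 9800 nM, lies within the scatter of both other compounds. The next structure, compound 4 `O=S(=O)(/C=C/c1ccc(O)c(O)c1)CC1CC1`, has cyclopropyl in place of cyclohexylmethyl on a saturated chain carbon bound to a sulfonyl sulfur. Among the compounds with values here, three measured steps bear on this change: a 1.1-fold higher number from compound 1 to compound 3 (0.05 log units; within the scatter), a 1.4-fold lower number from compound 1 to compound 2 (0.14 log units; within the scatter) and a 1.5-fold higher number from compound 2 to compound 3 (0.19 log units; within the scatter). All three stay within the scatter, so no step beyond the scatter is expected in this assay. The expected step is a 1.1-fold lower number from compound 3 to compound 4 (0.04 log units; within the scatter). For compound 4 the estimated value is 9000 nM, with an expected range of 4500 nM to 18000 nM.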

Compound 4, half-maximal effective concentration: 10500 nM
Beside the measured number, compound 4's estimate is 1.2-fold (0.07 log units) below it; low and high end bracket the measured number.
By their numbers in this assay, from the lowest: compounds 2, 1, 3 and 4 (each within the scatter of the next).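

In this assay, cyclopropyl in place of cyclohexylmethyl on a saturated chain carbon bound to a sulfonyl sulfur gives a 1.1-fold higher number from compound 3 to compound 4 (0.03 log units; within the scatter). The other two comparisons agree, with a 1.2-fold higher number from compound 1 to compound 4 (0.08 log units; within the scatter) against cyclobutyl and a 1.6-fold higher number from compound 2 to compound 4 (0.22 log units; within the scatter) against hept-6-en-1-yl, so a side group of 3 heavy atoms sits within the scatter of those tried at this position, including one of 7 heavy atoms. No supporting data explain this flat response.

On these data alone, what an amine or a carboxylic acid at this position would do remains open. So does whether any group there moves the number beyond the scatter.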